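A few compounds are considered here, and "the series" means these few. Any claim that something is new, unique, unknown or untested is made for them only; others in the source may bear on it.

Series notes. The shared core carries a trifluoromethyl group and is varied at a single position. Compound 1 `CN(C)CCNc1nn2c(=O)cc(C(F)(F)F)nc2s1` bears an open chain at that position, and in an ADME assay on cells for inhibition of Intestinal-type alkaline phosphatase (Homo sapiens), read by luminescence, with stated times of 7 min and 20 min (on this read-out lower numbers stand for stronger inhibition and higher numbers for weaker inhibition), compound 1 gives 3750 nM. Within the data shown here, compound 2 `COc1ccccc1-c1nn2c(=O)cc(C(F)(F)F)nc2s1` carries instead a six-membered aromatic ring of carbon only that bears a methoxy group. In this assay compound 2 gives > 100000 nM, which is a limit of the assay and not a number. Compound 2 therefore stands at the weak end of the two values shown: the limit of > 100000 nM in this assay, at which 1 of the 2 values shown sits. Compound 3 `O=c1cc(C(F)(F)F)nc2sc(-c3ccccc3F)nn12` is the next variation and differs from compound 2 by fluoro in place of methoxy on an aromatic carbon. Among the measured compounds shown here, no measured pair shows the effect of this exchange, so the size of the step from compound 2 to compound 3 is not known from data. Compound 2 already sits at the limit, and a swap of one small substituent on the same ring is expected to leave the reading near that limit, with a step from compound 2 to compound 3 estimated at a number no higher from compound 2 to compound 3 (the limit leaves the size open), none beyond the scatter. Compound 3 is thus expected at 100000 nM, with a range from 30000 nM to 300000 nM, and most likely reported only as a limit again.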

Compound 3, half-maximal inhibitory concentration: > 100000 nM
Compound 3: no number, only a limit; the forecaster's own chance of this, stated with the estimate: 70%; the middle value sits exactly at the limit.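

Working notes on this position. The step between compound 2 and compound 3 cannot be read, as both ends are limits of the assay and not numbers, so the exchange of methoxy for fluoro has no measurable size here. The comparison with the open chain can be read: in this assay, 2-fluorophenyl in place of (2-(dimethylamino)ethyl)amino gives an at least 26-fold higher number from compound 1 to compound 3 (1.42 log units; beyond the scatter). With a second ring-bearing compound now at the limit, the weak reading at this position no longer rests on the methoxy-bearing ring of compound 2 alone, since the fluoro-bearing ring of compound 3 sits there as well: the limit of > 100000 nM in this assay, at which 2 of the 3 values shown sit.

Compound 1 remains the only compound with a numerical reading, so the compounds shown leave open whether that reading goes with the dimethylamino group, with the linking amine or with the chain as a whole. Also open, on these data alone, is how a primary amine, a longer chain ending in dimethylamino, or a phenyl ring bearing an amine or a carboxylic acid would read at this position.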